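This account rests on a few compounds, and the source may have more. Where it says the series, first, only, none or still open, it means among the compounds named here.

Compound 1 `O=C(CN(c1ncnc2c1ncn2C1CCCCO1)C1CC1)NCC(=O)OCc1ccccc1` and compound 2 `O=C(CN(c1nc(Cl)nc2[nH]cnc12)C1CC1)N[C@@H](CO)C(=O)O` were both tested in a functional assay on the whole organism (Tail, strain ICR) with Mus musculus as the target, in the tail flick test, with a stated time of 60 min, at a dose of 25 umol/kg by the oral route; on this read-out higher numbers stand for a stronger effect at the one dose given and lower numbers for a weaker effect. In this assay compound 1 gives 40.4% and compound 2 gives 39.8%; the two numbers lie within the scatter of each other, so neither can be called the stronger. Compound 3 `NC(=O)C[C@H](NC(=O)CN(c1ncnc2c1ncn2C1CCCCO1)C1CC1)C(=O)OCc1ccccc1` has not yet been measured. It differs from compound 1 in one place: carbamoylmethyl in place of hydrogen on a saturated chain carbon bound to an amide-type nitrogen and a carbonyl carbon. For the measured compounds named here, no measured pair shows what such a change does here, so only a small step is expected, none beyond the scatter or a slight lowering, estimated as a number 3.4 percentage points lower from compound 1 to compound 3 (within the scatter). Compound 3 is accordingly estimated to give 37%, between 20% and 55%.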

Compound 3, a percentage reported as activity, at one dose (the size of the read-out at that dose, not a potency): 30.5%
Compound 3: the middle estimate sits 6.5 percentage points above what was measured, and the stated range covers the measured number.
By their numbers in this assay, from the lowest: compounds 3, 2 and 1 (each within the scatter of the next).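

In this assay the data show a number 9.9 percentage points lower from compound 1 to compound 3 (within the scatter) when carbamoylmethyl replaces hydrogen on a saturated chain carbon bound to an amide-type nitrogen and a carbonyl carbon. For the compounds shown here, this is the first measured change at this position, and adding this group moves the read-out by no more than the usual scatter, so no real loss can be claimed. No measured information bears on this step.

From the compounds shown here alone, it remains open whether a methyl group, an amine or a carboxylic acid on this same carbon would move the read-out beyond the scatter.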